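The compounds below may be only part of what the source reports. "The series", "measured", "known", "first", "only" and "open" are said of these compounds alone.

In a functional assay on L1210 cells (Mus musculus) for antiproliferative activity, with a stated time of 48 h (a lower number here means a stronger inhibitor, a higher number a weaker inhibitor), compound 1 `C=C(Br)C(=O)Nc1ccc(/C=C/C(=O)c2ccccc2)cc1` gives 5000 nM, compound 2 `C=C(Br)C(=O)Nc1ccc(/C=C/C(=O)c2ccc(Br)cc2)cc1` gives 620 nM, and compound 3 `Nc1ccc(/C=C/C(=O)c2ccc(Br)cc2)cc1` gives 90000 nM, the highest of the three numbers. Compound 4 `CCOc1ccc(C(=O)/C=C/c2ccc(N)cc2)cc1` differs from compound 3 by ethoxy in place of bromo on an aromatic carbon, with ethoxy in place of bromo on an aromatic carbon. The closest evidence is an 8.1-fold lower number from compound 1 to compound 2 (0.91 log units; beyond the scatter), a modest step in which bromo replaced hydrogen on that carbon, with the (1-bromoethenyl)carbonyl still on the nitrogen. The large 150-fold higher number from compound 2 to compound 3 (2.16 log units; beyond the scatter) concerns that nitrogen, which stays unchanged here. Among the measured compounds shown here, no measured step tests ethoxy, so a modest step at most is expected in this assay, in no firm direction. The expected change is a 1.3-fold lower number from compound 3 to compound 4 (0.11 log units; within the scatter). Compound 4 is estimated at 70000 nM, within 20000 nM to 200000 nM.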

Compound 4, half-maximal inhibitory concentration: 21000 nM
Compound 4: middle estimate off by 3.3-fold (0.52 log units), on the high side; measured number inside the range.
By their numbers in this assay, from the lowest: compound 2; then compound 1; then compound 4; then compound 3.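

With the nitrogen unsubstituted, ethoxy in place of bromo on the aromatic carbon para to a large group moves this assay by a 4.3-fold lower number from compound 3 to compound 4 (0.63 log units; beyond the scatter) and so, unlike the earlier bromo and hydrogen pair, tests a group with an oxygen at this position. Bromo is therefore not the group with the lower number in this pair, although it gave the lower number against hydrogen when the (1-bromoethenyl)carbonyl was on the nitrogen. Nothing measured here explains this change.

The compounds shown leave open whether ethoxy would give a step of similar size and direction with the (1-bromoethenyl)carbonyl on the nitrogen. They also leave open how methoxy, a longer alkoxy chain or a hydroxy group would compare at this carbon.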